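Amide nitrogen variation in a shared diaryl thiophene amide series

A few compounds are considered here, and "the series" means these few. Any claim that something is new, unique, unknown or untested is made for them only; others in the source may bear on it.

Measured so far in a functional assay on A549 cells (Homo sapiens) for inhibition, read by sulforhodamine B assay, with a stated time of 72 h; a higher number here means a weaker inhibitor, a lower number a stronger inhibitor:
compound 1 `Nc1sc(-c2ccc(Cl)cc2)c(-c2ccc(Cl)cc2)c1C(=O)NC1CCC(O)CC1` gives 250 nM
compound 2 `CC(C)(C)NC(=O)c1c(N)sc(-c2ccc(Cl)cc2)c1-c1ccc(Cl)cc1` gives 8850 nM
compound 3 `COc1ccc(CNC(=O)c2c(N)sc(-c3ccc(Cl)cc3)c2-c2ccc(Cl)cc2)cc1` gives 18200 nM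

Compound 3 stands highest of the three numbers, a 2.1-fold higher number from compound 2 to compound 3 (0.31 log units; beyond the scatter) and a 73-fold higher number from compound 1 to compound 3 (1.86 log units; beyond the scatter). Compound 4 `CC1CCN(C(=O)c2c(N)sc(-c3ccc(Cl)cc3)c2-c2ccc(Cl)cc2)CC1` carries 4-methylpiperidin-1-yl in place of (4-methoxybenzyl)amino on a carbonyl carbon. Among the compounds with values here, no measured step exchanges an amide hydrogen-bearing substituent for a ring-closed nitrogen, so the bearing steps are indirect: a 35-fold higher number from compound 1 to compound 2 (1.55 log units; beyond the scatter) and a 2.1-fold higher number from compound 2 to compound 3 (0.31 log units; beyond the scatter) show that every departure from 4-hydroxycyclohexyl has given a higher number, with the two groups lacking a hydroxyl sitting close together. Compound 4 is therefore expected to stay in the weaker range, estimated at 10000 nM (range 2500 nM to 40000 nM), which means an expected 1.8-fold lower number from compound 3 to compound 4 (0.26 log units; within the scatter).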

Compound 4, half-maximal inhibitory concentration: 1750 nM
The estimate for compound 4 lay 5.7-fold (0.76 log units) above the measured number, outside the stated range (below it).
By their numbers in this assay, from the lowest: compound 1; then compound 4; then compound 2; then compound 3.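

Having no amide hydrogen does not keep this position in the weak range: 4-methylpiperidin-1-yl on the carbonyl carbon gives a 10-fold lower number from compound 3 to compound 4 (1.02 log units; beyond the scatter) and a 5.1-fold lower number from compound 2 to compound 4 (0.70 log units; beyond the scatter). Nor does lacking a hydroxyl alone set the weak range, although 4-hydroxycyclohexyl stays lowest of the four, with a 7.0-fold higher number from compound 1 to compound 4 (0.85 log units; beyond the scatter). No measurement at hand explains these differences.

Open, from the compounds shown here alone, is how 4-hydroxypiperidin-1-yl on this carbonyl carbon would compare with compound 1 and compound 4. That comparison would help separate the contribution of the hydroxyl from that of the amide hydrogen.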